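From 3-methoxyphenyl to 4-butoxyphenyl on a shared core

The compounds below may be only part of what the source reports. "The series", "measured", "known", "first", "only" and "open" are said of these compounds alone.

- compound 1 `COc1ccc(/C=C/c2cc(OC)cc(OC)c2/C=C/C(=O)c2ccc(Cl)c(Cl)c2)cc1`: 5.9 ug/mL
- compound 2 `COc1ccc(/C=C/c2cc(OC)cc(OC)c2/C=C/C(=O)c2cccc(OC)c2)cc1`: 6.1 ug/mL
- compound 3 `COc1ccc(/C=C/c2cc(OC)cc(OC)c2/C=C/C(=O)c2ccc(C)cc2)cc1`: 3.6 ug/mL

In a functional assay on A549 cells (Homo sapiens) for antiproliferative activity, read by MTT assay, with a stated time of 48 h (on this read-out higher numbers stand for weaker inhibition and lower numbers for stronger inhibition), compound 2 gives 6.1 ug/mL, which lies within the scatter of the other two compounds. Compound 4 `CCCCOc1ccc(C(=O)/C=C/c2c(/C=C/c3ccc(OC)cc3)cc(OC)cc2OC)cc1` has 4-butoxyphenyl in place of 3-methoxyphenyl on a carbonyl carbon. Three measured swaps at that place bear on this change: a 1.0-fold higher number from compound 1 to compound 2 (0.01 log units; within the scatter), a 1.6-fold lower number from compound 1 to compound 3 (0.21 log units; within the scatter) and a 1.7-fold lower number from compound 2 to compound 3 (0.23 log units; within the scatter). For the measured compounds named here, all three stayed within the scatter, so no step beyond the scatter is expected in this assay, although no butoxy group has yet been measured here. The expected change is a 1.2-fold lower number from compound 2 to compound 4 (0.09 log units; within the scatter). Compound 4 is estimated at 5 ug/mL, with an expected range from 2.2 ug/mL to 11 ug/mL.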

Compound 4, half-maximal inhibitory concentration: 8.7 ug/mL
Estimate against measurement, compound 4: 1.7-fold (0.24 log units) below; the measured number falls inside the stated range.
By their numbers in this assay, from the lowest: compounds 3, 1, 2 and 4 (each within the scatter of the next, the first and the last beyond it).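

In this assay, for the compounds shown here, only one step at this position goes beyond the scatter, butoxy in place of methyl on an aromatic carbon, which gives a 2.4-fold higher number from compound 3 to compound 4 (0.38 log units; beyond the scatter) and is modest. Against the other two groups, 4-butoxyphenyl stays within the scatter, with a 1.4-fold higher number from compound 2 to compound 4 (0.15 log units; within the scatter) and with a 1.5-fold higher number from compound 1 to compound 4 (0.17 log units; within the scatter) as the steps. Nothing available explains these results.

From the compounds shown here alone, whether the number follows the length of the chain remains open, and a propoxy or hexyloxy group on the same phenyl ring would test that. An amine or a carboxylic acid there would show whether a different kind of group moves the number further.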